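Extending Compound 1 with a (4-Fluorobenzyl)oxy Group

The compounds below may be only part of what the source reports. "The series", "measured", "known", "first", "only" and "open" are said of these compounds alone.

Going by the values given here, compound 1 `Cc1cccc(Cl)c1NC(=O)c1cc2ccccc2oc1=O` gives 19100 nM in an in vitro assay on BTI-TN-5B1-4 cells for inhibition of Amine oxidase [flavin-containing] B (Homo sapiens), read by fluorescence (on this read-out lower numbers stand for stronger inhibition and higher numbers for weaker inhibition), the higher of the two numbers measured so far. Among the compounds with values here, its only neighbour, compound 2 `Cc1cccc(C)c1NC(=O)c1cc2ccccc2oc1=O`, gives 1290 nM, so the one known step, a 15-fold lower number from compound 1 to compound 2 (1.17 log units; beyond the scatter), is large. Compound 3 `Cc1cccc(Cl)c1NC(=O)c1cc2ccc(OCc3ccc(F)cc3)cc2oc1=O` differs from compound 1 at a different place: (4-fluorobenzyl)oxy in place of hydrogen on an aromatic carbon. Within the data shown here, no measured step tests this kind of change, so nothing measured bears directly on it, and the expected step of a 1.6-fold lower number from compound 1 to compound 3 (0.20 log units; within the scatter) carries wide uncertainty. For compound 3 the estimate in this assay is 12000 nM, within 1500 nM to 80000 nM.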

Compound 3, half-maximal inhibitory concentration: 41600 nM
Estimate against measurement, compound 3: 3.5-fold (0.54 log units) below; low and high end bracket the measured number.
By their numbers in this assay, from the lowest: compound 2; then compound 1; then compound 3.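

Putting (4-fluorobenzyl)oxy on an aromatic carbon of the shared core, a place the earlier pair left unchanged, produces a 2.2-fold higher number from compound 1 to compound 3 (0.34 log units; beyond the scatter) and thus a modest loss of inhibition. This position therefore accepts the added benzyl ether and its extra ring without any gain in inhibition on compound 1. No available evidence explains this rise.

From the compounds shown here alone, whether a methoxy, a hydroxyl or an amine at the same position would also raise the number remains open. So does whether (4-fluorobenzyl)oxy would have the same effect on compound 2.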